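Aryl exchange on the five-membered ring: compound 3 to compound 4

A few compounds are considered here, and "the series" means these few. Any claim that something is new, unique, unknown or untested is made for them only; others in the source may bear on it.

Three compounds have been measured in a functional assay on MCF7 cells (Homo sapiens) for inhibition, read by MTT assay, with a stated time of 24 h; a higher number here means a weaker inhibitor, a lower number a stronger inhibitor:
Compound 1 `CCOC(=O)C1=Cc2ccccc2OC1(OCc1cc(-c2ccc3ccccc3c2)no1)C(F)(F)F`: 65400 nM
Compound 2 `CCOC(=O)C1=Cc2ccccc2OC1(OCc1cc(-c2ccc(Br)cc2)no1)C(F)(F)F`: > 150000 nM
Compound 3 `CCOC(=O)C1=Cc2ccccc2OC1(OCc1cc(-c2ccc([N+](=O)[O-])cc2)no1)C(F)(F)F`: > 150000 nM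

Compound 1 gives a number, whereas compound 3 sits at the limit of > 150000 nM in this assay, at which 2 of the 3 values shown sit, a limit of the assay and not a number. Compound 2 sits at the same limit. The measured steps are an at least 2.2-fold higher number from compound 1 to compound 2 (0.36 log units; beyond the scatter) and an at least 2.2-fold higher number from compound 1 to compound 3 (0.36 log units; beyond the scatter), while a step that the two limits leave unreadable from compound 2 to compound 3.

Compound 4 `CCOC(=O)C1=Cc2ccccc2OC1(OCc1cc(-c2cccc(C(F)(F)F)c2)no1)C(F)(F)F` differs from compound 3 by 3-(trifluoromethyl)phenyl in place of 4-nitrophenyl on an aromatic carbon. Among the measured compounds shown here, no measured step covers a trifluoromethyl-bearing phenyl, so the only guidance is that compound 3 and compound 2 both sit at the limit. Compound 4 is therefore expected to stay near that limit, estimated at 150000 nM with a range from 60000 nM to 300000 nM. The expected step is a number no higher from compound 3 to compound 4 (the limit leaves the size open).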

Compound 4, half-maximal inhibitory concentration: 22100 nM
The estimate for compound 4 lay 6.8-fold (0.83 log units) above the measured number; measured number outside the range, below it.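

In this assay, a single phenyl ring on the five-membered ring can still give a readable number: 3-(trifluoromethyl)phenyl brings an at least 6.7-fold lower number from compound 3 to compound 4 (0.83 log units; beyond the scatter) and an at least 6.7-fold lower number from compound 2 to compound 4 (0.83 log units; beyond the scatter). Both steps start from a limit of the assay and not a number: the limit of > 150000 nM in this assay, at which 2 of the 4 values shown sit. The same group also brings a 3.0-fold lower number from compound 1 to compound 4 (0.47 log units; beyond the scatter), so compound 4 is the strongest inhibitor of the four, ahead of the fused naphthalen-2-yl group.

On these data alone, whether this gain follows the trifluoromethyl group itself or its place on the phenyl ring stays open. Also open, as far as these compounds go, is whether an amine or a carboxylic acid on that ring would keep it.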